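Removing a linker: compound 3 toward compound 4

This account rests on a few compounds, and the source may have more. Where it says the series, first, only, none or still open, it means among the compounds named here.

Three compounds share a core and were tested in an ADME assay on L02 cells (Homo sapiens) for inhibition, read by CCK-8 assay, with a stated time of 48 h; on this read-out lower numbers stand for stronger inhibition of growth and higher numbers for weaker inhibition of growth. Compound 1 `Cc1ccccc1Nc1nc(Nc2cc(Cl)ccn2)ncc1Cl` gives 41500 nM. Compound 2 `Cc1ccccc1Nc1nc(Nc2ccc(N3CCCN(C)CC3)cc2)ncc1Cl` gives 1240 nM. Compound 3 `COc1ccc(CNc2nc(Nc3ccc(N4CCN(C)CC4)cn3)ncc2Cl)cc1` gives 12900 nM. On these numbers compound 3 stands second highest: compound 1 sits higher, beyond the scatter, and compound 2 sits lower, well beyond the scatter, so compound 2 shows the strongest inhibition of growth among the three.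

Compound 4 `COc1cccc(Nc2nc(Nc3ccc(N4CCN(C)CC4)cn3)ncc2Cl)c1` is not yet measured. It differs from compound 3 in one place: 3-methoxyphenyl in place of 4-methoxybenzyl on a nitrogen on an aromatic ring. The step from compound 3 to compound 4 is expected to lower the number beyond the scatter, because compound 2 gives 1240 nM with a six-membered aromatic ring of carbon only on that nitrogen, and compound 3 with its benzyl group sits far higher. The step is estimated at a 2.9-fold lower number from compound 3 to compound 4 (0.46 log units; beyond the scatter). Compound 4 is therefore expected to give about 4500 nM in this assay, with a plausible range from 1500 nM to 15000 nM.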

Compound 4, concentration for 50% growth inhibition: 3470 nM
Compound 4: the middle estimate sits 1.3-fold (0.11 log units) above what was measured, within the range that was stated.
By their numbers in this assay, from the lowest: compound 2; then compound 4; then compound 3; then compound 1.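

Putting 3-methoxyphenyl in place of 4-methoxybenzyl on a nitrogen on an aromatic ring gives a 3.7-fold lower number from compound 3 to compound 4 (0.57 log units; beyond the scatter) in this assay. Among these compounds, this is the first single change that can be read in this set, and it shows that growth inhibition in this assay responds to the group at this position. The response comes from a small change: 9 heavy atoms leave and 8 enter, and both groups carry one six-membered aromatic ring of carbon only, but no measurement here explains the step.

The step joins two differences, the loss of the carbon that links the ring to the nitrogen and the change from a 4-methoxy to a 3-methoxy pattern, and the compounds shown do not separate them. A 4-methoxyphenyl or a 3-methoxybenzyl group on the same nitrogen would tell the two apart.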